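The compounds below may be only part of what the source reports. "The series", "measured", "known", "first", "only" and "open" are said of these compounds alone.

In an ADME assay on cells (Fibroblast, Homo sapiens) for cytotoxicity, with a stated time of 48 h (a higher number here means a weaker inhibitor, a lower number a stronger inhibitor), compound 1, whose structure is `O=[N+]([O-])c1ccc(CN2CCC(n3cc(CC(OCc4cc(-c5ccc(F)cc5)no4)c4ccc(Br)cc4)nn3)CC2)cc1`, reaches only a limit of the measurement, reported as > 25000 nM. Compound 2, with the structure `COc1ccc(-c2cc(COC(Cc3cn(C4CCN(Cc5ccc([N+](=O)[O-])cc5)CC4)nn3)c3ccc(Br)cc3)on2)cc1`, likewise gives in this assay only a limit, > 25000 nM. Compound 3, drawn as `O=[N+]([O-])c1ccc(CN2CCC(n3cc(CC(OCc4cc(-c5ccccc5F)no4)c4ccc(Br)cc4)nn3)CC2)cc1`, again gives no number in this assay but a limit, > 25000 nM. Compound 4, the structure `COc1ccccc1-c1cc(COC(Cc2cn(C3CCN(Cc4ccc([N+](=O)[O-])cc4)CC3)nn2)c2ccc(Br)cc2)on1`, has not yet been measured in this assay.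

Compound 2 differs from compound 1 by methoxy in place of fluoro on an aromatic carbon, and the step from compound 1 to compound 2 in this assay is a step that the two limits leave unreadable from compound 1 to compound 2. The two cores, that of compound 1 and that of compound 3, differ by 2-fluorophenyl in place of 4-fluorophenyl on an aromatic carbon. Compound 4 differs from compound 3 by methoxy in place of fluoro on an aromatic carbon. Among the compounds with values here, this is the same kind of change as the one from compound 1 to compound 2, but not the same: in compound 2 the methoxy sits para to a large group, while in compound 4 it sits ortho to a large group.

Within the data shown here, for compound 3 to compound 4 in this assay, the step expected is a step that the limit leaves unreadable from compound 3 to compound 4, resting on the fact that (the limit of > 25000 nM in this assay, at which 3 of the 3 values shown sit), so that no reading of a step is possible from compound 1 to compound 2 and nothing points away from the limit. Compound 4 is therefore expected to be reported near 30000 nM, most likely again as a limit rather than a number, within the range from 15000 nM to 60000 nM.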

Compound 4, half-maximal inhibitory concentration: > 25000 nM
Compound 4 ended at the assay's limit (the forecaster's own chance of this, stated with the estimate: 85%); the middle value does not contradict the limit.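

In this assay compound 4 gives only a limit, > 25000 nM, and not a number. Within the data shown here, no step from compound 1, compound 2 or compound 3 to compound 4 can therefore be read, and all four compounds stand at the same limit: the limit of > 25000 nM in this assay, at which 4 of the 4 values shown sit. The compounds shown leave open whether methoxy in place of fluoro changes the value in this assay at all.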